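A few compounds are considered here, and "the series" means these few. Any claim that something is new, unique, unknown or untested is made for them only; others in the source may bear on it.

Measured compounds:
- compound 1, `CCOc1nc(-c2cc3ccccc3o2)cc(-c2ccc3ccccc3c2)c1C#N`: 423000 nM
- compound 2, `COc1nc(-c2cc3ccccc3o2)cc(-c2ccc(Cl)cc2)c1C#N`: 286000 nM
- compound 3, `CCOc1nc(-c2cc3ccccc3o2)cc(-c2ccc(Cl)cc2)c1C#N`: 221000 nM

All three numbers come from a functional assay on aorta (strain Wistar) for inhibition, with Thoracic aorta (Rattus norvegicus) as the target; a lower number here means a stronger inhibitor, a higher number a weaker inhibitor. Compound 2 sits close to both of its neighbours: the difference a 1.3-fold lower number from compound 2 to compound 3 (0.11 log units; within the scatter) is within the scatter, and the numbers of compound 2 and compound 1 also differ by less than the scatter, so no order can be read among the three.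

Compound 4, `COc1nc(-c2cc3ccccc3o2)cc(-c2ccc(F)cc2)c1C#N`, has not yet been tested in this assay. It differs from compound 2 by fluoro in place of chloro on an aromatic carbon. Going by the values given here, no measured step exchanges one halogen for another, so the closest guides are the two steps seen so far: a 1.9-fold lower number from compound 1 to compound 3 (0.28 log units; within the scatter), which replaced the whole aromatic group at that position, and a 1.3-fold lower number from compound 2 to compound 3 (0.11 log units; within the scatter), which altered the alkoxy group, both within the scatter. A swap of one halogen for another at the same place is a smaller change than either, so the expected step of a 1.0-fold higher number from compound 2 to compound 4 (0.02 log units; within the scatter) is within the scatter. Compound 4 is therefore expected to give about 300000 nM in this assay, with a likely range from 140000 nM to 650000 nM.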

Compound 4, half-maximal inhibitory concentration: 321000 nM
Beside the measured number, compound 4's estimate is 1.1-fold (0.03 log units) below it, within the range that was stated.
By their numbers in this assay, from the lowest: compounds 3, 2, 4 and 1 (each within the scatter of the next).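

Before compound 4, the only change at this aromatic carbon was the exchange of a whole aromatic group, so the halogen itself had not been varied. In this assay, exchanging chloro for fluoro, on a carbon para to a large group, gives a 1.1-fold higher number from compound 2 to compound 4 (0.05 log units; within the scatter) and so shows no difference that can be told from the scatter, which means that 4-chlorophenyl and 4-fluorophenyl cannot be ranked here. Nothing available explains this result or bears on it.

The compounds shown carry only chloro and fluoro as small groups at this place, so they leave open whether an amine or a carboxylic acid in place of the halogen would shift the number beyond the scatter. They also leave open whether a longer chain in place of the methoxy or ethoxy group would change the number in this assay at all.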